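Sulfur for Oxygen in a Dichlorophenyl Linker

The compounds below may be only part of what the source reports. "The series", "measured", "known", "first", "only" and "open" are said of these compounds alone.

Compound 1 `Nc1cc(N)c2nc(-c3ccccc3)c(Oc3ccc(Cl)c(Cl)c3)nc2c1`: 63100 nM
Compound 2 `COc1ccc(CNc2nc3cc(N)cc(N)c3nc2-c2ccccc2)cc1OC`: 32400 nM
Compound 3 `COc1cc(CNc2nc3cc(N)cc(N)c3nc2-c2ccccc2)cc(OC)c1OC`: 17800 nM

These three values come from a functional assay on TK-10 cells (Homo sapiens) for inhibition, read by sulforhodamine B assay, with a stated time of 48 h; a lower number here means a stronger inhibitor of growth, a higher number a weaker inhibitor of growth. Compound 1 gives the highest number of the three; compound 2 sits nearest, with 32400 nM, and compound 3 furthest, with 17800 nM, the gap to compound 3 being beyond the scatter while the gap to compound 2 is within it. Going by the values given here, the only measured step, a 1.8-fold lower number from compound 2 to compound 3 (0.26 log units; within the scatter), concerns a methoxy group on the side arm and lies within the scatter.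

Compound 4 `Nc1cc(N)c2nc(-c3ccccc3)c(Sc3ccc(Cl)c(Cl)c3)nc2c1` differs from compound 1 by a single change: (3,4-dichlorophenyl)sulfanyl in place of 3,4-dichlorophenoxy on an aromatic carbon. Among the compounds with values here, no measured step touches this exchange of oxygen for sulfur, so there is nothing to anchor a directional expectation; the one step on record says only that a small change on the arm left this assay almost unchanged. Compound 4 is therefore expected to show a 1.1-fold lower number from compound 1 to compound 4 (0.06 log units; within the scatter), no shift beyond the scatter. The estimate for compound 4 is 55000 nM, within the range 20000 nM to 150000 nM.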

Compound 4, concentration for total growth inhibition: 20000 nM
Compound 4: the middle estimate sits 2.8-fold (0.44 log units) above what was measured, and the stated range covers the measured number.
By their numbers in this assay, from the lowest: compounds 3, 4, 2 and 1 (each within the scatter of the next, the first and the last beyond it).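

Going by these compounds alone, at this carbon next to the ring nitrogen, (3,4-dichlorophenyl)sulfanyl in place of 3,4-dichlorophenoxy gives a 3.2-fold lower number from compound 1 to compound 4 (0.50 log units; beyond the scatter) in this assay and lies beyond the scatter, whereas the only earlier step, a 1.8-fold lower number from compound 2 to compound 3 (0.26 log units; within the scatter) on the side arm, lies within it. The two groups match in heavy atom count, hydrogen-bond donors, hydrogen-bond acceptors and charge, and the dichlorophenyl ring is the same in both, so sulfur for oxygen in the link is all that separates the two compounds. The data shown offer no measurement that accounts for this shift.

The compounds shown leave open how a methylene link or a sulfone link at the same carbon would read. They also leave open whether sulfur for oxygen gives a similar step when the ring carries methoxy groups instead of the two chlorines.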